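Fluoro for chloro on the pyrazoline aryl group

A few compounds are considered here, and "the series" means these few. Any claim that something is new, unique, unknown or untested is made for them only; others in the source may bear on it.

Of the compounds shown here, three have been measured in a functional assay on the whole organism (strain Wistar) for inhibition, with Rattus norvegicus as the target, read by paw edema, with a stated time of 30 min, at a dose of 50 mg/kg by the oral route; a higher number here means more inhibition at the dose given (going by the name of the read-out), a lower number less inhibition. Compound 1 `O=CN1N=C(c2ccc(F)cc2)CC1c1cn(-c2ccccc2)nc1-c1ccc(Cl)c(Cl)c1` gives 37.2%, compound 2 `Fc1ccc(C2=NN(c3ccccc3)C(c3cn(-c4ccccc4)nc3-c3ccc(Cl)c(Cl)c3)C2)cc1` gives 44.7%, and compound 3 `Clc1ccc(C2=NNC(c3cn(-c4ccccc4)nc3-c3ccc(Cl)c(Cl)c3)C2)cc1` gives 33%. Compound 3 holds the lowest of the three numbers: its gap to compound 1 lies within the scatter, while its gap to compound 2 lies beyond it. Among the compounds with values here, the only measured step that changes one place, a number 7.5 percentage points higher from compound 1 to compound 2 (within the scatter), concerns a different position and does not touch the change considered here.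

Compound 4 `Fc1ccc(C2=NNC(c3cn(-c4ccccc4)nc3-c3ccc(Cl)c(Cl)c3)C2)cc1` differs from compound 3 in one place: fluoro in place of chloro on an aromatic carbon. Within the data shown here, no measured pair shows this exchange on its own, so nothing in the data points to a move in either direction beyond the scatter. The step from compound 3 to compound 4 is therefore expected to be small, a number 3 percentage points higher from compound 3 to compound 4 (within the scatter), lying within the usual scatter. On this basis compound 4 is estimated at 36%, with a range from 26% to 46%.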

Compound 4, a percentage reported as inhibition, in the whole organism at one dose (the size of the read-out at that dose, not a potency): 45.7%
Compound 4: the middle estimate sits 9.7 percentage points below what was measured; low and high end bracket the measured number.
By their numbers in this assay, from the lowest: compounds 3, 1, 2 and 4 (each within the scatter of the next, the first and the last beyond it).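

Going from 4-chlorophenyl to 4-fluorophenyl is the first exchange at this position seen on its own, and in this assay it gives a number 12.7 percentage points higher from compound 3 to compound 4 (beyond the scatter) and so is not neutral here. With 4-fluorophenyl in place, the group on the ring nitrogen makes no difference that stands out from the scatter: hydrogen in place of phenyl gives a number 1 percentage points higher from compound 2 to compound 4 (within the scatter) and hydrogen in place of formyl gives a number 8.5 percentage points higher from compound 1 to compound 4 (within the scatter) in this series. No measurement at hand accounts for the rise seen with fluoro.

The compounds shown leave open how a methyl, a methoxy or a plain hydrogen would fare in place of the halogen on this phenyl ring. They also leave open whether chloro and fluoro would differ in the same way with phenyl or formyl on the ring nitrogen.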